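Cyclopropyl for cyclohexyl on the urea nitrogen in the series

This account rests on a few compounds, and the source may have more. Where it says the series, first, only, none or still open, it means among the compounds named here.

Measured so far in a functional assay on the whole organism for inhibition, with Rattus norvegicus as the target, at a dose of 30 mg/kg by the oral route; on this read-out lower numbers stand for less inhibition and higher numbers for more inhibition at the one dose given (going by the name of the read-out):
compound 1 `CN(C(=O)NCCCOc1ccc2nc(O)ccc2c1)C1CCCCC1` gives 15%
compound 2 `O=C(NCCCOc1ccc2[nH]c(=O)ccc2c1)N(C1CC1)[C@@H]1CCCC[C@H]1O` gives 24%; 29% (2 entries)
compound 3 `O=C(NCCCOc1ccc2nc(O)ccc2c1)N(C1CCCCC1)[C@H]1CCCC[C@@H]1O` gives 18%

Compound 3 holds the higher of the two single numbers, with compound 1 the nearest; the step of a number 3 percentage points higher from compound 1 to compound 3 (within the scatter) separates them, so no order is claimed. Compound 2 has only the repeat entries (the several entries of compound 2 in this assay, 24%; 29% (2 entries)). Compound 4 `O=C(NCCCOc1ccc2nc(O)ccc2c1)N(C1CC1)[C@H]1CCCC[C@@H]1O` differs from compound 3 by cyclopropyl in place of cyclohexyl on an amide-type nitrogen. Among the measured compounds shown here, no measured step covers this exchange. Compound 2 carries cyclopropyl on the same nitrogen together with the ring opposite in configuration to compound 4, and its repeats the several entries of compound 2 in this assay, 24%; 29% (2 entries) lie near compound 3. A step within the scatter is therefore expected, a number 4 percentage points higher from compound 3 to compound 4 (within the scatter). Compound 4 is estimated at 22%, between 10% and 35%.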

Compound 4, a percentage reported as inhibition, in the whole organism at one dose (the size of the read-out at that dose, not a potency): 13%
Estimate against measurement, compound 4: 9 percentage points above; low and high end bracket the measured number.
By their numbers in this assay, from the lowest: compounds 4, 1 and 3 (each within the scatter of the next).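

In this assay, cyclopropyl in place of cyclohexyl on the amide-type nitrogen gives a number 5 percentage points lower from compound 3 to compound 4 (within the scatter). Among the compounds shown here, this is the first direct reading of that exchange, and at this one dose the read-out does not separate the two rings. Together with a number 3 percentage points higher from compound 1 to compound 3 (within the scatter), neither exchange at this nitrogen has yet moved the number beyond the scatter.

Still open, on these data alone, is whether an isopropyl group or a piperidine ring on this nitrogen would move the number. The role of ring configuration is also open, with compound 2 opposite in configuration to compound 4: the several entries of compound 2 in this assay, 24%; 29% (2 entries)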